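From chloro to methoxy on compound 1

A few compounds are considered here, and "the series" means these few. Any claim that something is new, unique, unknown or untested is made for them only; others in the source may bear on it.

compound 1 (`Nc1ccccc1NC(=O)c1ccc(COc2ccc(Cl)cc2)cc1`): > 32000 nM
compound 2 (`Nc1ccccc1NC(=O)/C=C/c1ccc(COc2ccccc2)cc1`): > 32000 nM

In a functional assay on HepG2 cells (Homo sapiens) for antiproliferative activity, read by CCK-8 assay, with a stated time of 72 h (a higher number here means a weaker inhibitor, a lower number a stronger inhibitor), compound 1 gives > 32000 nM as a limit of the assay, not a number. Compound 2 likewise gives > 32000 nM as a limit. Compound 3 (`COc1ccc(OCc2ccc(C(=O)Nc3ccccc3N)cc2)cc1`) carries methoxy in place of chloro on an aromatic carbon, para to a large group (methoxy in place of chloro on an aromatic carbon). For the measured compounds named here, no measured step bears on this change in this assay and none beyond the scatter is expected. The estimated step of a number no higher from compound 1 to compound 3 (the limit leaves the size open) is therefore expected to have no clear direction. Compound 3 is expected at 32000 nM within a range from 12000 nM to 80000 nM if the reading gives a number at all.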

Compound 3, half-maximal inhibitory concentration: 4200 nM
Estimate against measurement, compound 3: 7.6-fold (0.88 log units) above; the measured number lies below the stated range.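

In this assay, methoxy in place of chloro on the aromatic carbon gives an at least 7.6-fold lower number from compound 1 to compound 3 (0.88 log units; beyond the scatter), so this position, para to a large group, responds to the group it carries. Of the three compounds shown, only compound 3 gives a number rather than a limit. The full size of the step stays open because compound 1 stands at a limit: the limit of > 32000 nM in this assay, at which 2 of the 3 values shown sit.

From the compounds shown here alone, it remains open whether a hydroxyl, an amine or a longer alkoxy chain at this position would do the same. Going by these compounds, it is also open whether methoxy would lower the number on the core of compound 2.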